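One group exchanged on compound 1

A few compounds are considered here, and "the series" means these few. Any claim that something is new, unique, unknown or untested is made for them only; others in the source may bear on it.

In an ADME assay on L6 cells (Rattus norvegicus) for cytotoxicity, read by resazurin assay, with a stated time of 72 h (a higher number here means that more compound is needed for the effect, a lower number that less compound is needed), compound 1 `CCOC(=O)C1=C(C)N/C(=C/c2cc(C)n(-c3ccc(CN(C)C)cc3)c2C)C1=O` gives 120000 nM. Two relatives have also been measured: compound 2 `CCOC(=O)C1=C(O)/C(=C\c2cc(C)n(-c3ccc(F)cc3)c2C)N=C1C` gives 140000 nM, and compound 3 `CCOC(=O)C1=C(C)N/C(=C/c2cc(C)n(-c3cccc(O)c3)c2C)C1=O` gives 69000 nM. Compound 1 lies within the usual scatter of both, so these numbers cannot rank it against either one.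

Compound 4 `CCOC(=O)C1=C(C)N/C(=C/c2cc(C)n(-c3ccc(SC(F)(F)F)cc3)c2C)C1=O` keeps the core of compound 1 and alters a single group: (trifluoromethyl)sulfanyl in place of (dimethylamino)methyl on an aromatic carbon. In words, (trifluoromethyl)sulfanyl takes the place of (dimethylamino)methyl on an aromatic carbon of a six-membered aromatic ring of carbon only, para to a large group.

Among the measured compounds shown here, only one measured step touches this part of compound 1. With 3-hydroxyphenyl in place of 4-((dimethylamino)methyl)phenyl on an aromatic nitrogen, compound 3 shows a 1.7-fold lower number from compound 1 to compound 3 (0.24 log units; within the scatter). For the measured compounds named here, that is a different replacement, so it serves only as a loose guide, and no measured compound carries (trifluoromethyl)sulfanyl. Nothing here therefore points firmly in either direction, and no change beyond the scatter is expected in this assay.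

The expected change is a 1.3-fold lower number from compound 1 to compound 4 (0.12 log units; within the scatter).

For compound 4 the estimated value is 90000 nM, with an expected range from 30000 nM to 200000 nM.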

Compound 4, half-maximal effective concentration: 140000 nM
Beside the measured number, compound 4's estimate is 1.6-fold (0.19 log units) below it, within the range that was stated.
By their numbers in this assay, from the lowest: compounds 3, 1, 2 and 4 (each within the scatter of the next, the first and the last beyond it).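

In this assay, the exchange of (dimethylamino)methyl for (trifluoromethyl)sulfanyl gives a 1.2-fold higher number from compound 1 to compound 4 (0.07 log units; within the scatter). The earlier step replaced the whole 4-((dimethylamino)methyl)phenyl group, whereas this one alters only the group on an aromatic carbon, para to a large group, and it shows that two groups with entirely different atoms, one holding nitrogen and the other fluorine and sulfur, can stand at this place without the number leaving the scatter. No measured evidence on any property of these two groups accompanies this result, so the pair describes the outcome of the exchange and gives no explanation for it.

On these data alone, this is a single pair on a single core, so it does not show that this position tolerates every group, and it remains open whether a carboxylic acid or a longer alkyl chain on the same aromatic carbon would also stay within the scatter. As far as these compounds go, it also remains open whether an amine attached directly to that carbon, without the methyl link of (dimethylamino)methyl, would give a number beyond the scatter of compound 1.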